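The source may hold more compounds than are shown below. What is called first, only, known or untested is meant among the compounds shown, and "the series" means these compounds.

Measured compounds, each tested in a functional assay on A549 cells (Homo sapiens) for inhibition, read by CCK-8 assay, with a stated time of 72 h, tested at 1 uM; a higher number here means a stronger effect of the compound at the concentration tested, a lower number a weaker effect:

compound 1, `CN(C)C(=O)c1cc2cnc(Nc3ccc(C(=O)NCCCCCN=C=S)cc3F)nc2n1C1CCCC1`, gives -1.6%;
compound 2, `CN(C)C(=O)c1cc2cnc(Nc3ccc(C(=O)NCCCCCCN=C=S)cc3F)nc2n1C1CCCC1`, gives -11.8%;
compound 3, `CN(C)C(=O)c1cc2cnc(Nc3ccc(NC(=O)CCCN=C=S)cc3)nc2n1C1CCCC1`, gives 56.1%.

Compound 1 and compound 2 share one core and differ only in the tail of the chain. The change from compound 1 to compound 2 is a group of 4 heavy atoms (2 carbon, 1 nitrogen, 1 sulfur; no ring) in place of a group of 3 heavy atoms (1 carbon, 1 nitrogen, 1 sulfur; no ring), on a saturated chain carbon, five bonds along the chain from an amide-type nitrogen. That change made a number 10.2 percentage points lower from compound 1 to compound 2 (beyond the scatter), so lengthening the chain at this position cost a little activity in this assay, with the step lying beyond the usual scatter.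

Compound 3 has a different core from compound 1; the difference between the two cores is not broken down here. In this assay compound 3 gives the highest of the three numbers, and its steps to compound 1 and to compound 2 are both beyond the scatter.

Compound 4, `CN(C)C(=O)c1cc2cnc(Nc3ccc(NC(=O)CCCCN=C=S)cc3)nc2n1C1CCCC1`, has not yet been measured. It arises from compound 3 by a group of 4 heavy atoms (2 carbon, 1 nitrogen, 1 sulfur; no ring) in place of a group of 3 heavy atoms (1 carbon, 1 nitrogen, 1 sulfur; no ring), on a saturated chain carbon, three bonds along the chain from a carbonyl carbon. Among the compounds with values here, this is the same kind of change as the one from compound 1 to compound 2, but not the same change: in the earlier pair the place is five bonds along the chain from an amide-type nitrogen, whereas here it is three bonds along the chain from a carbonyl carbon, so the chain is shorter and the surroundings differ.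

Within the data shown here, only one earlier example of this kind of change exists, and it is on another core, so any expectation rests on thin ground. The step from compound 3 to compound 4 is expected to be about a number 10.1 percentage points lower from compound 3 to compound 4 (beyond the scatter), close to the earlier one, because that earlier step was a number 10.2 percentage points lower from compound 1 to compound 2 (beyond the scatter). Compound 4 is therefore estimated at 46%, somewhere between 25% and 65%.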

Compound 4, a percentage reported as inhibition, at one concentration (the size of the read-out at that concentration, not a potency): 38.2%
Compound 4: the middle estimate sits 7.8 percentage points above what was measured, and the stated range covers the measured number.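

In this assay, putting the group of 4 heavy atoms in place of the group of 3 heavy atoms on the core of compound 3 gave a number 17.9 percentage points lower from compound 3 to compound 4 (beyond the scatter), so the number fell here as it did on the core of compound 1. Set side by side, the two steps point the same way and cannot be told apart in size: the same change on two cores in this assay, a number 10.2 percentage points lower (beyond the scatter) from compound 1 to compound 2 and a number 17.9 percentage points lower (beyond the scatter) from compound 3 to compound 4, 7.7 percentage points apart, within the scatter of two such steps This shows that the change carried over between these two cores, but two pairs make no general rule, the place of the change is not the same in both pairs, and nothing here shows why the number falls.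

The compounds shown leave open whether a shorter chain or a still longer chain on the core of compound 3 would continue this fall, and what an amine or a carboxylic acid at the tail of the chain would do in place of the present group. They also leave open whether the same picture would hold at other concentrations, as each number is a read-out at a single concentration and not a potency.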